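The compounds below may be only part of what the source reports. "The series", "measured", "known", "first", "only" and "open" are said of these compounds alone.

Compound 1, `Cc1ncc([N+](=O)[O-])n1CCSc1nnc(-c2ccccc2N)o1`: 20100 nM
Compound 2, `Cc1ncc([N+](=O)[O-])n1CCSc1nnc(-c2ccccc2[N+](=O)[O-])o1`: 18300 nM

In a functional assay on MCF7 cells (Homo sapiens) for cytotoxicity, read by MTT assay, with a stated time of 48 h (on this read-out higher numbers stand for weaker inhibition and lower numbers for stronger inhibition), compound 1 stands with the highest of the two numbers, and its nearest neighbour is compound 2; the step of a 1.1-fold lower number from compound 1 to compound 2 (0.04 log units; within the scatter) lies within the scatter, so the two compounds cannot be told apart on this read-out. Compound 3, `Cc1ncc([N+](=O)[O-])n1CCSc1nnc(-c2ccccn2)o1`, differs from compound 1 by pyridin-2-yl in place of 2-aminophenyl on an aromatic carbon. Among the compounds with values here, only one measured step bears on this change, the step of a 1.1-fold lower number from compound 1 to compound 2 (0.04 log units; within the scatter), in which the group on that aromatic carbon was altered without moving the number beyond the scatter. Within the data shown here, with that single step as the only guide, a step beyond the scatter from compound 1 to compound 3 is not expected in either direction. Compound 3 is therefore estimated to give 19000 nM, within a range from 8000 nM to 45000 nM. The expected step of a 1.1-fold lower number from compound 1 to compound 3 (0.02 log units; within the scatter) is estimated to stay within the scatter.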

Compound 3, half-maximal inhibitory concentration: 39100 nM
Estimate against measurement, compound 3: 2.1-fold (0.31 log units) below; measured number inside the range.
By their numbers in this assay, from the lowest: compounds 2, 1 and 3 (each within the scatter of the next, the first and the last beyond it).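

Exchanging the whole 2-aminophenyl group for pyridin-2-yl swaps a carbon-only ring for one holding a ring nitrogen and removes the hydrogen-bond donor, yet in this assay the result is a 1.9-fold higher number from compound 1 to compound 3 (0.29 log units; within the scatter). So this position, on an aromatic carbon of the five-membered ring, has now taken a change to the ring itself without a step beyond the scatter, whereas the earlier step altered only a group on the phenyl ring. Nothing measured here accounts for these numbers.

The compounds shown leave open what a plain phenyl ring, with no amino or nitro group, would give at this position. They also leave open whether a saturated ring such as cyclohexyl or an open chain such as butyl would stay within the scatter.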